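The source may hold more compounds than are shown below. What is called first, only, known or untested is meant among the compounds shown, and "the series" means these compounds.

Notes on the series. In a functional assay on K562 cells (Homo sapiens) for cytotoxicity, read by trypan blue exclusion, with a stated time of 96 h (on this read-out higher numbers stand for weaker inhibition and lower numbers for stronger inhibition), compound 1 (`COc1cc(OC)c(/C=C/S(=O)(=O)Cc2ccc(OC)c(N)c2)c(OC)c1`) gives 2.5 nM, while compound 2 (`COc1ccc(CS(=O)(=O)/C=C/c2c(OC)cc(O)cc2OC)cc1[N+](=O)[O-]`) gives 5000 nM, the higher of the two numbers and far beyond the scatter. Compound 3 (`COc1ccc(CS(=O)(=O)/C=C/c2c(OC)cc(O)cc2OC)cc1N`) arises from compound 2 by one change, amino in place of nitro on an aromatic carbon. Among the compounds with values here, no measured step isolates this change. Compound 1, which also carries an amino group, stands at 2.5 nM, so a clearly lower number is expected in this assay, beyond the scatter. The expected step is a 50-fold lower number from compound 2 to compound 3 (1.70 log units; beyond the scatter). For compound 3 the estimated value is 100 nM, with an expected range of 10 nM to 1000 nM.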

Compound 3, half-maximal inhibitory concentration: 300 nM
For compound 3 the middle estimate is 3.0-fold (0.48 log units) below the measured one; the measured number falls inside the stated range.
By their numbers in this assay, from the lowest: compound 1; then compound 3; then compound 2.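

In this assay the change on this aromatic carbon, ortho to a methoxy group, counts on its own, with amino in place of nitro giving a 17-fold lower number from compound 2 to compound 3 (1.22 log units; beyond the scatter) on the same core. The amino group does not by itself reach the level of compound 1: hydrogen in place of methyl on an oxygen on an aromatic ring gives a 120-fold higher number from compound 1 to compound 3 (2.08 log units; beyond the scatter) in a second large step. The data give no explanation for either step.

Open, from the compounds shown here alone, is how an acetamide or a dimethylamino group would behave in place of the amino group. Also open, going by these compounds, is how an ethyl ether would behave in place of the methyl ether on that oxygen.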